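A few compounds are considered here, and "the series" means these few. Any claim that something is new, unique, unknown or untested is made for them only; others in the source may bear on it.

In an ADME assay on Huh-7 cells (Homo sapiens) for cytotoxicity, with a stated time of 72 h (a higher number here means that more compound is tolerated, a lower number that less compound is tolerated), three compounds have been measured so far, and each of them returns a limit rather than a number. Compound 1 `CC(C)CCn1nc(-c2cccs2)c(O)c(C2=NS(=O)(=O)c3cc(NS(=O)(=O)C(C)C)ccc3N2)c1=O` reaches only the limit of > 1000 nM. Compound 2 `CS(=O)(=O)Nc1ccc2c(c1)S(=O)(=O)N=C(c1c(O)c(-c3ccc(Cl)s3)nn(CCC3CC3)c1=O)N2` reaches the limit of > 33000 nM. Compound 3 `CC(C)CCn1nc(-c2ccccc2)c(O)c(C2=NS(=O)(=O)c3cc(NS(C)(=O)=O)ccc3N2)c1=O` likewise stands at the limit of > 1000 nM; this is where most of the values sit (the limit of > 1000 nM in this assay, at which 2 of the 3 values shown sit), while one value sits at a higher limit (the limit of > 33000 nM in this assay, at which 1 of the 3 values shown sits). Among the compounds with values here, every value shown is a limit, and no step between measured compounds is at hand. Compound 4 `CC(C)CCn1nc(CC(C)C)c(O)c(C2=NS(=O)(=O)c3cc(NS(C)(=O)=O)ccc3N2)c1=O` has not yet been measured in this assay. It differs from compound 3 by isobutyl in place of phenyl on an aromatic carbon. Within the data shown here, no measured step resembles this change, so no step beyond the usual scatter is expected from compound 3 to compound 4 in this assay, and the outcome is most likely another limit. The estimate for compound 4 in this assay is 5000 nM, expected to fall between 1000 nM and 50000 nM. That figure is expected to mean a step that the limit leaves unreadable from compound 3 to compound 4 in this assay.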

Compound 4, half-maximal cytotoxic concentration: > 1000 nM
Compound 4 gave a limit, no number (the forecaster's own chance of this, stated with the estimate: 75%); the middle value lies beyond the limit too.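

Compound 3 and compound 4 both return only limits in this assay, and no step can be read between them. The compounds shown leave open how far either lies beyond its limit, and whether isobutyl in place of phenyl changes the tolerated concentration at all.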